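Furan-3-yl in place of vinyl: an expected step

A few compounds are considered here, and "the series" means these few. Any claim that something is new, unique, unknown or untested is made for them only; others in the source may bear on it.

Compound 1 `C=CC(O)C1=CC(=O)c2ccccc2C1=O` carries a vinyl group on a saturated chain carbon bound to a double-bonded ring carbon and an oxygen on a saturated carbon. In a functional assay on WHCO1 cells (Homo sapiens) for cytotoxicity, read by MTT assay, with a stated time of 24 h (on this read-out lower numbers stand for stronger inhibition and higher numbers for weaker inhibition), compound 1 gives 4300 nM, the lowest of the two numbers recorded so far. The other measured compound, compound 2 `O=C(C1=CC(=O)c2ccccc2C1=O)c1ccc(F)cc1`, bears a different substituent on the shared core; in this assay compound 2 gives 74900 nM, a number far above that of compound 1 and beyond the usual scatter. For the measured compounds named here, no step between these two has been worked out, so only their two values stand.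

Compound 3 `O=C1C=C(C(O)c2ccoc2)C(=O)c2ccccc21` differs from compound 1 in one place: furan-3-yl in place of vinyl on a saturated chain carbon bound to a double-bonded ring carbon and an oxygen on a saturated carbon. The chain carbon with its oxygen is kept, and only the vinyl is exchanged. Neither measured compound shows what such an exchange does here, so the expectation rests on compound 1 alone. Compound 3 is expected to stay near compound 1, with an estimated step of a 1.4-fold higher number from compound 1 to compound 3 (0.14 log units; within the scatter) that may not reach beyond the scatter. The estimate for compound 3 in this assay is 6000 nM, within a range from 2000 nM to 20000 nM.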

Compound 3, half-maximal inhibitory concentration: 10900 nM
The estimate for compound 3 lay 1.8-fold (0.26 log units) below the measured number; the measured number falls inside the stated range.
By their numbers in this assay, from the lowest: compound 1; then compound 3; then compound 2.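

The exchange of vinyl for furan-3-yl gives the first step read at this position: in this assay it amounts to a 2.5-fold higher number from compound 1 to compound 3 (0.40 log units; beyond the scatter). The position therefore responds to what the saturated chain carbon carries, yet the larger group with its five-membered aromatic ring costs only a modest step, and compound 3 gives 10900 nM. Nothing at hand accounts for the size or direction of this step, since no other measurement bears on it.

This single step cannot separate the contribution of the aromatic ring from that of the ring oxygen, or show whether the double bond of the vinyl group matters, so a phenyl group, a furan-2-yl group or a plain ethyl group on the same carbon would be needed to tell these apart. Also open, on these data alone, is what the oxygen on the saturated carbon contributes when furan-3-yl is present, which a methyl ether or an amine at that place would begin to show.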